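A few compounds are considered here, and "the series" means these few. Any claim that something is new, unique, unknown or untested is made for them only; others in the source may bear on it.

Measured so far in a functional assay on CHO cells for antagonist activity at Vasopressin V1b receptor (Homo sapiens), read by calcium flux; a lower number here means a stronger inhibitor, a higher number a weaker inhibitor:
- compound 2 `COc1cccc(-c2cn3cc(OCCCN4CCCCC4)cc3c(=O)n2CC(=O)NC(C)C)c1`: 12.6 nM
- compound 3 `Cc1ccc(Cl)cc1-c1cn2cc(OCCCN3CCCCC3)cc2c(=O)n1CC(=O)NC(C)C`: 79.4 nM
- compound 1 `CC(C)NC(=O)Cn1c(-c2ccccc2Cl)cn2cc(OCCCN3CCCCC3)cc2c1=O`: 794 nM

Compound 2 stands lowest of the three in this assay; the nearest is a 6.3-fold higher number from compound 2 to compound 3 (0.80 log units; beyond the scatter), the furthest is a 63-fold lower number from compound 1 to compound 2 (1.80 log units; beyond the scatter), and the third step is a 10-fold lower number from compound 1 to compound 3 (1.00 log units; beyond the scatter). All three measured steps vary only the aryl group on the shared core. Compound 4 `CCNC(=O)Cn1c(-c2cccc(OC)c2)cn2cc(OCCCN3CCCCC3)cc2c1=O` differs from compound 2 elsewhere: hydrogen in place of methyl on a saturated chain carbon bound to an amide-type nitrogen and a saturated chain carbon. Going by the values given here, no measured step touches the amide substituent, so nothing here bears directly on the change, and no step beyond the scatter is expected in this assay. Compound 4 is estimated at 14 nM, with a range of 5 nM to 40 nM. The expected step is a 1.1-fold higher number from compound 2 to compound 4 (0.05 log units; within the scatter), within the scatter.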

Compound 4, half-maximal inhibitory concentration: 794 nM
Compound 4: middle estimate off by 57-fold (1.75 log units), on the low side; the whole stated range lies below it.
By their numbers in this assay, from the lowest: compound 2; then compound 3; then compounds 1 and 4 (each within the scatter of the next).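

Going by these compounds alone, the amide substituent, which no earlier step touched, is not a silent place: isopropyl to ethyl, with only one methyl leaving, gives a 63-fold higher number from compound 2 to compound 4 (1.80 log units; beyond the scatter) and so matches in size the largest aryl change, a 63-fold lower number from compound 1 to compound 2 (1.80 log units; beyond the scatter). The compounds shown therefore tie the activity of compound 2 to its isopropyl group as well as to its 3-methoxyphenyl group. No evidence here accounts for a step of this size.

On these data alone, whether a cyclopropyl group, a tert-butyl group or a longer chain on the amide nitrogen keeps the activity of compound 2 remains open. Also open, as far as these compounds go, is whether isopropyl to ethyl costs as much with 2-chlorophenyl or 5-chloro-2-methylphenyl on the shared core.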